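This account rests on a few compounds, and the source may have more. Where it says the series, first, only, none or still open, it means among the compounds named here.

Working notes on the series. In a functional assay on HepG2 cells (Homo sapiens) for antiproliferative activity, read by MTT assay, with a stated time of 24 h (a higher number here means a weaker inhibitor, a lower number a stronger inhibitor), compound 1 `COc1ccc(C(=O)/C=C/c2cccc(F)c2)c2c1C=CC(C)(C)O2` gives > 10000 nM as a limit of the assay. Compound 2 `COc1ccc(C(=O)/C=C/c2ccccc2Cl)c2c1C=CC(C)(C)O2` gives > 10000 nM as a limit too. Compound 3 `COc1ccccc1/C=C/C(=O)c1ccc(OC)c2c1OC(C)(C)C=C2` gives > 10000 nM as a limit as well. Compound 3 therefore has no number of its own and stands with the other two at the limit of > 10000 nM in this assay, at which 3 of the 3 values shown sit, in these notes.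

The step to compound 4 `COc1ccc(C(=O)/C=C/c2cccc(O)c2)c2c1C=CC(C)(C)O2` is 3-hydroxyphenyl in place of 2-methoxyphenyl on a double-bonded chain carbon bound to a double-bonded chain carbon and puts a 3-hydroxyphenyl where the 2-methoxyphenyl stood. The measured steps that bear on it are a step that the two limits leave unreadable from compound 1 to compound 2 and a step that the two limits leave unreadable from compound 1 to compound 3 and a step that the two limits leave unreadable from compound 2 to compound 3 and none of them has a readable size. The nearest counterpart to the 3-hydroxyphenyl is the 3-fluorophenyl of compound 1, which stays at > 10000 nM as a limit.

No step beyond the scatter is expected in this assay in either direction, and the estimated a number no higher from compound 3 to compound 4 (the limit leaves the size open) stands for that expectation. For compound 4 the estimate is 10000 nM with an expected range from 3000 nM to 30000 nM.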

Compound 4, half-maximal inhibitory concentration: > 10000 nM
Compound 4: no number, only a limit (the forecaster's own chance of this, stated with the estimate: 70%); the middle value sits exactly at the limit.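

No step to compound 4 from compound 1, compound 2 or compound 3 can be read, because each result is a limit and not a number: the limit of > 10000 nM in this assay, at which 4 of the 4 values shown sit.

The compounds shown leave open whether any group in this place on the shared core gives a measurable value in this assay.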